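The source may report more compounds than this note shows. Statements on the series, on what has been measured and on what is new or still open speak of the compounds shown alone.

Working notes on the series. In a functional assay on MDA-MB-468 cells (Homo sapiens) for inhibition (on this read-out lower numbers stand for stronger inhibition and higher numbers for weaker inhibition), compound 1 `Nc1ccc(-c2nc3ccccc3s2)c(Br)c1` gives < 0.1 nM, which is a limit of the assay rather than a number. Compound 2 `Cc1ccc2nc(-c3ccc(N)cc3Br)sc2c1` also sits at a limit in this assay, giving < 0.1 nM. The step that the two limits leave unreadable from compound 1 to compound 2 therefore cannot be sized. Compound 3 `Nc1ccc(-c2nc3cc(Oc4ccccc4)ccc3s2)cc1Cl` in this assay gives > 10000 nM, again a limit; compound 3 differs from compound 1 in more than one place, so their two values show only that each sits at an opposite end of what the assay reports. Compound 4 `Nc1ccc(-c2nc3ccccc3s2)c(O)c1` differs from compound 1 by hydroxy in place of bromo on an aromatic carbon. Going by the values given here, no measured step exchanges a bromo for a hydroxy, and the evidence at hand, the limit of < 0.1 nM in this assay, at which 2 of the 3 values shown sit, and (the limit of > 10000 nM in this assay, at which 1 of the 3 values shown sits), tells only where the values sit. Among the compounds with values here, with compound 1 itself at a limit, the starting point is open, and the expectation for compound 4 rests on no measured step at all. The estimate for compound 4 is accordingly wide: an expected value of 50 nM, between 0.1 nM and 5000 nM. This expected value corresponds to an estimated step of an at least 500-fold higher number from compound 1 to compound 4 (2.69 log units; beyond the scatter).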

Compound 4, half-maximal inhibitory concentration: > 10000 nM
Compound 4 was reported as a limit; the forecaster's own chance of this, stated with the estimate: 25%; middle value at least 200-fold (2.30 log units) from the limit.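

The step from bromo to hydroxy on this aromatic carbon, ortho to a group of 9 heavy atoms and meta to the amino group, is an at least 100000-fold higher number from compound 1 to compound 4 (5.00 log units; beyond the scatter), and it spans the two ends of what this assay reports. Both ends of this step are limits of the assay, so it gives a lower bound on the size and no exact value. Going by these compounds alone, it is still the first readable step, since the step for methyl in place of hydrogen cannot be read, and it shows that the read-out at this one position does not tolerate every exchange of a single heavy atom.

The compounds shown do not separate the loss of bromo from the entry of hydroxy; a methoxy, a methyl or a plain hydrogen on this carbon would tell the two apart. Also open, on these data alone, is whether hydroxy in place of bromo has the same outcome on the methyl-bearing core of compound 2, and no measured property here accounts for the step.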